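From a Pentyl Chain to a Chlorophenyl Ring

The source may hold more compounds than are shown below. What is called first, only, known or untested is meant among the compounds shown, and "the series" means these compounds.

In a functional assay for inhibition of sodium/hydrogen exchanger (Oryctolagus cuniculus) (a higher number here means a weaker inhibitor, a lower number a stronger inhibitor), compound 1 `CCCc1cc(C)c(C(=O)N=C(N)N)cc1S(C)(=O)=O` gives 5.7 nM, and compound 2 `CCCCCc1cc(C)c(C(=O)N=C(N)N)cc1S(C)(=O)=O` gives 27 nM. Going by the values given here, compound 2 therefore holds the higher of the two numbers, and the only measured step, a 4.7-fold higher number from compound 1 to compound 2 (0.68 log units; beyond the scatter), came from lengthening the chain. Compound 3 `Cc1cc(-c2ccc(Cl)cc2)c(S(C)(=O)=O)cc1C(=O)N=C(N)N` differs from compound 2 by 4-chlorophenyl in place of pentyl on an aromatic carbon. Among the compounds with values here, no measured step swaps a chain for a ring, so that single step offers only a loose guide, and little movement beyond the scatter is expected in this assay. Compound 3 is thus estimated at 20 nM, with a range from 5 nM to 100 nM. That would be an expected step of a 1.4-fold lower number from compound 2 to compound 3 (0.13 log units; within the scatter).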

Compound 3, half-maximal inhibitory concentration: 45 nM
Compound 3: middle estimate off by 2.3-fold (0.35 log units), on the low side; the range from low to high includes it.
By their numbers in this assay, from the lowest: compound 1; then compounds 2 and 3 (each within the scatter of the next).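

In this assay, the result shows that this aromatic carbon, ortho to a methylsulfonyl group, accepts a ring as well as a chain: the exchange of pentyl for 4-chlorophenyl gives only a small difference (a 1.7-fold higher number from compound 2 to compound 3 (0.22 log units; within the scatter)). Against the propyl group of the shared core, the same ring gives a clearer loss (a 7.9-fold higher number from compound 1 to compound 3 (0.90 log units; beyond the scatter)), so propyl remains the best-placed group here. Nothing available explains these differences. As far as these compounds go, it remains open how an ethyl chain, a phenyl ring without the chlorine, or an amine at this carbon would compare with compound 1.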